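Swapping the acetylpiperidine of compound 2 for a dimethylimidazole

The source may report more compounds than this note shows. Statements on the series, on what has been measured and on what is new or still open speak of the compounds shown alone.

Compound 1 `CNC(=O)c1ncc(-c2cnc(NCc3c(F)ccc4c3CCO4)c3cn[nH]c(=O)c23)n1C`: 2.5
Compound 2 `CC(=O)N1CCC(c2cnc(NCc3c(F)ccc4c3CCO4)c3cn[nH]c(=O)c23)CC1`: 2.9

Going by the values given here, in a physicochemical assay for lipophilicity, using the shake flask method, in phosphate buffer, measured as octanol-water partition, with a stated time of 30 min, at pH 7.4 (a lower number here means a more polar compound, a higher number a more lipophilic compound), compound 2 stands highest of the two numbers measured; the nearest is compound 1, and the single step of a number 0.40 log units higher from compound 1 to compound 2 (beyond the scatter) lies beyond the scatter. Compound 3 `Cc1ncc(-c2cnc(NCc3c(F)ccc4c3CCO4)c3cn[nH]c(=O)c23)n1C` is not yet measured in this assay. It differs from compound 2 in one place: 1,2-dimethyl-1H-imidazol-5-yl in place of 1-acetylpiperidin-4-yl on an aromatic carbon. Among the compounds with values here, the only measured step that bears on it is a number 0.40 log units higher from compound 1 to compound 2 (beyond the scatter), which shares the leaving group but puts in place of it a different imidazole, one carrying a methylcarbamoyl where compound 3 carries a methyl. Within the data shown here, no measured pair isolates that carbamoyl-to-methyl exchange, so the step into compound 3 cannot be read off directly. Compound 3 is therefore expected to land near compound 2, with a step of no change at the digits printed from compound 2 to compound 3 (within the scatter) not beyond the scatter. The estimate for compound 3 is 2.9, within 2.4 to 3.4.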

Compound 3, distribution coefficient: 1.9
The estimate for compound 3 lay 1.00 log units above the measured number; measured number outside the range, below it.
By their numbers in this assay, from the lowest: compound 3; then compound 1; then compound 2.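

In this assay the 1,2-dimethyl-1H-imidazol-5-yl group gives the lowest number of the three compounds, with a number 1.00 log units lower from compound 2 to compound 3 (beyond the scatter) and a number 0.60 log units lower from compound 1 to compound 3 (beyond the scatter). Going by these compounds alone, the second of these steps is the first to isolate a change on the imidazole itself, showing that methyl in place of methylcarbamoyl moves the number down, in the opposite direction to what the estimate assumed for an imidazole at this position. Nothing available here accounts for the direction or size of either step.

Going by these compounds, it remains open how other groups would read in place of that methyl, such as an amine, a carboxylic acid or a longer alkyl chain. Also open, on these data alone, is how a piperidine without the acetyl would compare at this position.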